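The source may hold more compounds than are shown below. What is called first, only, known or untested is meant among the compounds shown, and "the series" means these compounds.

Three compounds sharing one core and a long saturated chain have been tested in a functional assay on cells (Homo sapiens) for cytotoxicity, read by MTT assay, with a stated time of 24 h; on this read-out higher numbers stand for weaker inhibition and lower numbers for stronger inhibition. Compound 1 `CCCCCCCCCCCCCCNC(=O)[C@H](CO)/N=C/c1cccc(OC)c1` gives 31300 nM, compound 2 `CCCCCCCCCCCCCCNC(=O)[C@H](CO)NCc1ccccc1O` gives 75300 nM, and compound 3 `CCCCCCCCCCCCCCNC(=O)[C@H](CO)NCc1ccccc1OC` gives 100000 nM. Compound 2 thus stands second highest of the three numbers. Compound 4 `CCCCCCCCCCCCCCNC(=O)[C@H](CO)/N=C/c1ccccc1` differs from compound 2 in one place: a group of 8 heavy atoms (7 carbon, 1 nitrogen; one six-membered aromatic ring of carbon only) in place of a group of 9 heavy atoms (7 carbon, 1 nitrogen, 1 oxygen; one six-membered aromatic ring of carbon only), on a saturated chain carbon bound to a carbonyl carbon and a saturated chain carbon. For the measured compounds named here, two measured steps bear on this: a 2.4-fold higher number from compound 1 to compound 2 (0.38 log units; beyond the scatter) and a 3.2-fold higher number from compound 1 to compound 3 (0.50 log units; beyond the scatter) both exchange the group of compound 1, which carries a double bond outside aromatic rings, for one without it, and both raise the number, so restoring that double bond should lower it modestly. The step of a 1.3-fold higher number from compound 2 to compound 3 (0.12 log units; within the scatter) is within the scatter. Compound 4 is therefore expected to give 35000 nM, between 15000 nM and 80000 nM, an estimated step of a 2.2-fold lower number from compound 2 to compound 4 (0.33 log units; beyond the scatter).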

Compound 4, half-maximal inhibitory concentration: 7670 nM
Compound 4: the middle estimate sits 4.6-fold (0.66 log units) above what was measured; measured number below the stated range.
By their numbers in this assay, from the lowest: compound 4; then compound 1; then compounds 2 and 3 (each within the scatter of the next).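

In this assay the step of a 4.1-fold lower number from compound 1 to compound 4 (0.61 log units; beyond the scatter) keeps the double bond outside aromatic rings and changes only the ring, with hydrogen in place of methoxy, so that ring position matters on its own. The steps of a 9.8-fold lower number from compound 2 to compound 4 (0.99 log units; beyond the scatter) and a 13-fold lower number from compound 3 to compound 4 (1.12 log units; beyond the scatter) go the same way, but each also brings in the double bond, so they cannot separate the two changes.

On these data alone, whether a plain benzylamino group, with no ring oxygen, would give a similarly low number remains open, as does the effect of a fluorine on the ring. No measurement here explains these steps.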